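Swapping an amino for a chloro on a sulfonamide

The compounds below may be only part of what the source reports. "The series", "measured", "known", "first", "only" and "open" are said of these compounds alone.

Measured compounds:
- compound 1, `CC1CCN(C2CCN(S(=O)(=O)c3cccc(N)c3)CC2)CC1`: > 5000 nM
- compound 2, `CC(=O)Nc1ccc(S(=O)(=O)N2CCC(N3CCC(C)CC3)CC2)c2ccccc12`: > 10000 nM
- compound 3, `COc1ccc(NC(=O)N2CCC(N3CCC(C)CC3)CC2)cc1`: > 5000 nM

The three compounds share a core built from two saturated rings joined through a nitrogen, and each was tested in an ADME assay on HCT-116 cells (Homo sapiens) for cytotoxicity, read by CellTiter-Glo, with a stated time of 72 h; a higher number here means a weaker inhibitor, a lower number a stronger inhibitor. None of them gave a number. For compound 1 the result is a limit of the assay, > 5000 nM, which says only that no inhibition was found up to that concentration. For compound 2 the result is likewise a limit, > 10000 nM. For compound 3 it is again a limit, > 5000 nM. Compound 1 therefore sits at the limit of > 5000 nM in this assay, at which 2 of the 3 values shown sit, and compound 2 sits at the limit of > 10000 nM in this assay, at which 1 of the 3 values shown sits.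

Compound 4, `CC1CCN(C2CCN(S(=O)(=O)c3cccc(Cl)c3)CC2)CC1`, has not yet been measured. It differs from compound 1 in a single place: chloro in place of amino on an aromatic carbon. Among the measured compounds shown here, with no step between measured compounds to draw on, the expectation for this assay is a change no larger than the usual scatter, in no particular direction. The estimate for compound 4 is therefore 8000 nM, in a range from 2000 nM to 30000 nM, and the expected step that the limit leaves unreadable from compound 1 to compound 4 is essentially flat, most likely reported again as a limit.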

Compound 4, half-maximal inhibitory concentration: > 5000 nM
Compound 4: a limit, no number (the forecaster's own chance of this, stated with the estimate: 75%); the middle value is on the limit's open side.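

In this assay compound 4 gives > 5000 nM, a limit and not a number. Compound 1 also stands at a limit, so no step can be read between compound 1 and compound 4. The compounds shown leave open whether chloro in place of amino changes cytotoxicity at all.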